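Swapping isopropyl for propyl on a shared core

The compounds below may be only part of what the source reports. "The series", "measured", "known", "first", "only" and "open" are said of these compounds alone.

Compound 1 `CCCc1cc(NNC(=O)Nc2cc(Cl)nc(Cl)c2)nc2c1c(C)nn2C`: 40800 nM
Compound 2 `CC(C)c1cc(NNC(=O)Nc2cc(Cl)nc(Cl)c2)nc2c1c(C(F)(F)F)nn2C`: 19100 nM

In a functional assay on SW620/5-FU cells (Homo sapiens) for cytotoxicity, read by MTT assay, with a stated time of 48 h, in the presence of a further agent that is not named here (a higher number here means that more compound is needed for the effect, a lower number that less compound is needed), compound 2 gives 19100 nM, the lower of the two numbers, and compound 1 gives 40800 nM. The gap between these two numbers lies beyond the scatter. Compound 3 `CCCc1cc(NNC(=O)Nc2cc(Cl)nc(Cl)c2)nc2c1c(C(F)(F)F)nn2C` has the same atoms as compound 2, joined differently: propyl in place of isopropyl on an aromatic carbon, with propyl in place of isopropyl on an aromatic carbon. Among the compounds with values here, no measured pair isolates this change, so its size in this assay is not known from the data. The expected outcome is a small 1.2-fold higher number from compound 2 to compound 3 (0.06 log units; within the scatter), with no shift beyond the scatter in either direction. The estimated value for compound 3 is 22000 nM, with an expected range of 11000 nM to 42000 nM.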

Compound 3, half-maximal effective concentration: 11700 nM
Compound 3: the middle estimate sits 1.9-fold (0.27 log units) above what was measured; the range from low to high includes it.
By their numbers in this assay, from the lowest: compounds 3 and 2 (each within the scatter of the next); then compound 1.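

In this assay, propyl in place of isopropyl on this aromatic carbon gives a 1.6-fold lower number from compound 2 to compound 3 (0.21 log units; within the scatter), so with trifluoromethyl held in place, the two chains cannot be told apart. With propyl held in place, trifluoromethyl in place of methyl gives a 3.5-fold lower number from compound 1 to compound 3 (0.54 log units; beyond the scatter), a single-place change that lies beyond the scatter, which the earlier pair, differing in two places, could not show. Nothing available explains either step.

From the compounds shown here alone, whether a longer chain such as butyl, or a cyclopropyl ring, on this carbon would shift the number remains open. So does the effect of an amine in place of the trifluoromethyl.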